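Chromone series: pyridinyl for cyclopentyl at the ring oxygen position

A few compounds are considered here, and "the series" means these few. Any claim that something is new, unique, unknown or untested is made for them only; others in the source may bear on it.

Measured so far:
compound 1 `O=c1cc(-c2cccnc2)oc2ccc(OCCCCCCN3CCC(O)CC3)cc12` — 210 nM
compound 2 `O=c1cc(C2CCCC2)oc2ccc(OCCCCCCN3CCCCC3)cc12` — 38 nM

Two compounds of the shared core have been run in an assay on isolated protein (Cavia porcellus) with Sigma non-opioid intracellular receptor 1 (Homo sapiens) as the target, read by radioligand binding; a higher number here means a weaker inhibitor, a lower number a stronger inhibitor. Compound 2 holds the lower of the two numbers; compound 1 sits higher, and the gap between them lies beyond the usual scatter, so compound 2 is the stronger inhibitor of the pair on what is shown. The two differ in more than one place, so neither place can be credited for the gap.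

Compound 3 `O=c1cc(-c2cccnc2)oc2ccc(OCCCCCCN3CCCCC3)cc12` is not yet measured. It differs from compound 2 in one place only: pyridin-3-yl in place of cyclopentyl on an aromatic carbon. The same pyridin-3-yl group stands in compound 1, but compound 1 also carries a different amine, so the pair gives no clean reading on this one change.

For the measured compounds named here, no single-change step is available between measured compounds. With compound 2 at 38 nM and compound 1 at 210 nM as the only anchors, a modest move toward a higher number is expected for compound 3, though a result within the scatter would not surprise. The expected step is a 2.4-fold higher number from compound 2 to compound 3 (0.37 log units; beyond the scatter). For compound 3 the estimate in this assay is 90 nM, with a range from 35 nM to 230 nM.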

Compound 3, half-maximal inhibitory concentration: 192 nM
The estimate for compound 3 lay 2.1-fold (0.33 log units) below the measured number, within the range that was stated.
By their numbers in this assay, from the lowest: compound 2; then compounds 3 and 1 (each within the scatter of the next).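

In this assay, for the compounds shown here, pyridin-3-yl in place of cyclopentyl on the aromatic carbon next to the ring oxygen gives a 5.1-fold higher number from compound 2 to compound 3 (0.70 log units; beyond the scatter), the first clean reading at this position, and it shows that the position responds to this exchange of rings. Hydrogen in place of hydroxy on a saturated ring carbon gives a 1.1-fold lower number from compound 1 to compound 3 (0.04 log units; within the scatter), so with pyridin-3-yl in place, this second change does not separate the pair beyond the scatter. The two differences between the earlier compounds can now be read apart, and only the exchange at the aromatic carbon lies beyond the scatter, but no measurement at hand bears on what lies behind that step.

The exchange alters ring size, aromaticity and the ring nitrogen together, and phenyl or cyclohexyl at this position would be needed to tell those features apart. Going by these compounds, whether hydroxy on the saturated ring is equally silent alongside cyclopentyl also stays open, as does the reading of either change with a shorter chain in place of the hexyl linker.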